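Swapping an Imidazole for a Cyanothiazole on the Amide

This account rests on a few compounds, and the source may have more. Where it says the series, first, only, none or still open, it means among the compounds named here.

Of the compounds shown here, three sharing one core have been tested in a functional assay on CHO cells for agonist activity at Free fatty acid receptor 2 (Homo sapiens), read by cAMP accumulation; a higher number here means a weaker inhibitor, a lower number a stronger inhibitor. Compound 1 `CC(C)[C@H](C(=O)NCc1ccccc1)c1ccc(Cl)cc1` carries a benzyl group on the amide nitrogen, and in this assay compound 1 reaches only > 100000 nM, which is a limit of the assay and not a number (the limit of > 100000 nM in this assay, at which 1 of the 3 values shown sits). Compound 2 `CC(C)[C@H](C(=O)Nc1ncns1)c1ccc(Cl)cc1` gives 2000 nM in this assay. Compound 3 `CC(C)[C@H](C(=O)Nc1ncc[nH]1)c1ccc(Cl)cc1` gives 20000 nM in this assay, the higher of the two numbers shown, so compound 3 is the weaker of the two measured compounds. The steps of an at least 50-fold lower number from compound 1 to compound 2 (1.69 log units; beyond the scatter) and an at least 5.0-fold lower number from compound 1 to compound 3 (0.69 log units; beyond the scatter) show that a small aromatic heterocycle on the amide nitrogen lowers the number, while a 10-fold higher number from compound 2 to compound 3 (1.00 log units; beyond the scatter) shows that the thiadiazole gives the lower number of the two rings.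

Compound 4 `CC(C)[C@H](C(=O)Nc1ncc(C#N)s1)c1ccc(Cl)cc1` differs from compound 3 in one place: 5-cyano-1,3-thiazol-2-yl in place of 1H-imidazol-2-yl on an amide-type nitrogen. The entering ring, with its sulfur and no hydrogen-bond donor, is closer in build to the ring of compound 2 than to that of compound 3, so the step in this assay is expected to be a clear drop, about a 25-fold lower number from compound 3 to compound 4 (1.40 log units; beyond the scatter). Compound 4 is therefore estimated at 800 nM, with a range from 150 nM to 4000 nM.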

Compound 4, half-maximal inhibitory concentration: 2000 nM
Beside the measured number, compound 4's estimate is 2.5-fold (0.40 log units) below it, within the range that was stated.
By their numbers in this assay, from the lowest: compounds 2 and 4 (each within the scatter of the next); then compound 3. At a limit, above all of these: compound 1.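

On the amide-type nitrogen, 5-cyano-1,3-thiazol-2-yl in place of 1H-imidazol-2-yl gives a 10-fold lower number from compound 3 to compound 4 (1.00 log units; beyond the scatter), while in place of 1,2,4-thiadiazol-5-yl it gives no change at the digits printed from compound 2 to compound 4 (within the scatter). The position therefore takes two different sulfur-containing rings without a hydrogen-bond donor at one level, even though one of them carries a nitrile, and the ring with a donor, 1H-imidazol-2-yl, gives the higher number. The step to the new ring from benzyl, an at least 50-fold lower number from compound 1 to compound 4 (1.69 log units; beyond the scatter), is only a bound, as compound 1 stands at a limit of the assay and not at a number: the limit of > 100000 nM in this assay, at which 1 of the 4 values shown sits.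

As far as these compounds go, whether the nitrile itself matters remains open, and a plain 1,3-thiazol-2-yl, or one carrying a methyl or a carboxylic acid instead, would test that. These rings also cannot separate the part played by the sulfur from that of the missing donor.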